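A Smaller Ether Group Replaces the Bicyclic One

The source may hold more compounds than are shown below. What is called first, only, known or untested is meant among the compounds shown, and "the series" means these compounds.

Among the measured compounds shown here, compound 2 `O=c1cc(OCc2cn(-c3ccc(S(=O)(=O)N4CCc5ccccc5C4)cc3)nn2)c2ccccc2o1` gives the highest number of the two measured so far in a functional assay on A549 cells (Homo sapiens) for cytotoxicity, read by MTT assay, with a stated time of 48 h; a lower number here means a stronger inhibitor, a higher number a weaker inhibitor: 25300 nM. Its nearest neighbour is compound 1 `COC(=O)c1ccccc1OCc1cn(-c2ccc(S(=O)(=O)N3CCc4ccccc4C3)cc2)nn1`, which in this assay gives 570 nM. For the measured compounds named here, the only step between them is a 44-fold higher number from compound 1 to compound 2 (1.65 log units; beyond the scatter), so replacing the single-ring ester-bearing group of compound 1 with the two-ring group of compound 2 cost a great deal of potency. Compound 3 `O=Cc1ccc(OCc2cn(-c3ccc(S(=O)(=O)N4CCc5ccccc5C4)cc3)nn2)cc1` moves back toward a single ring: a group of 8 heavy atoms (7 carbon, 1 oxygen; one six-membered aromatic ring of carbon only) in place of a group of 11 heavy atoms (9 carbon, 2 oxygen; one six-membered aromatic ring of carbon only, one six-membered aromatic ring with 1 hetero atom), on an oxygen on a saturated carbon. Going by the values given here, because the one step known, a 44-fold higher number from compound 1 to compound 2 (1.65 log units; beyond the scatter), shows that a single six-membered carbon ring at this oxygen goes with a far lower number than the two-ring group, a large drop is expected for compound 3, though its formyl group differs from the ester of compound 1, so the full return is uncertain. Compound 3 is estimated at 2500 nM, within 500 nM to 12000 nM, a step of a 10-fold lower number from compound 2 to compound 3 (1.01 log units; beyond the scatter).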

Compound 3, half-maximal inhibitory concentration: 59100 nM
Compound 3: the middle estimate sits 24-fold (1.37 log units) below what was measured, outside the stated range (above it).
By their numbers in this assay, from the lowest: compound 1; then compound 2; then compound 3.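

Compound 3 shows that a single six-membered carbon ring on this oxygen does not by itself give a low number: going to the smaller group brings a 2.3-fold higher number from compound 2 to compound 3 (0.37 log units; beyond the scatter), so losing the second ring brought no recovery in this assay. The comparison of the two single-ring groups is sharper, since 4-formylphenyl in place of 2-(methoxycarbonyl)phenyl gives a 100-fold higher number from compound 1 to compound 3 (2.02 log units; beyond the scatter), which means that what the ring carries, or where it carries it, matters far more here than the ring count. No measurement available here explains either step.

The compounds shown cannot separate the effect of swapping formyl for methoxycarbonyl from the effect of its place on the ring. They also leave open how an unsubstituted phenyl or a carboxylic acid-bearing phenyl would behave on this oxygen.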